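Ester for amide on the hydroxy branch of the series

The compounds below may be only part of what the source reports. "The series", "measured", "known", "first", "only" and "open" are said of these compounds alone.

Three compounds have numbers in an assay on HL-60 cells for agonist activity at vitamin D3 receptor (Homo sapiens), read by microscopy, with a stated time of 96 h (on this read-out lower numbers stand for an effect already at smaller amounts and higher numbers for an effect only at larger amounts of compound), so far. Compound 1 `CCn1c(C(=O)N(C)c2ccccc2)ccc1C(CC)(CC)c1ccc(OCC(=O)C(C)(C)C)c(C)c1` gives 18500 nM, compound 2 `CCn1c(C(=O)N(C)c2ccccc2)ccc1C(CC)(CC)c1ccc(OCC(O)C(C)(C)C)c(C)c1` gives 6400 nM and compound 3 `CCn1c(C(=O)OCc2ccc(F)cc2)ccc1C(CC)(CC)c1ccc(OCC(=O)C(C)(C)C)c(C)c1` gives 9500 nM. Compound 2 stands apart from compound 1 by the step of a 2.9-fold lower number from compound 1 to compound 2 (0.46 log units; beyond the scatter), which is beyond the scatter, while compound 3 sits within the scatter of compound 2. Compound 4 `CCn1c(C(=O)OCc2ccccn2)ccc1C(CC)(CC)c1ccc(OCC(O)C(C)(C)C)c(C)c1` is not yet measured. It differs from compound 2 in one place: (pyridin-2-yl)methoxy in place of methyl(phenyl)amino on a carbonyl carbon. Within the data shown here, the only measured step of a related kind is a 1.9-fold lower number from compound 1 to compound 3 (0.29 log units; within the scatter), where (4-fluorobenzyl)oxy replaced the same methyl(phenyl)amino on the carbonyl carbon with the (tert-butyl)carbonyl chain kept. That step was within the scatter. Among the measured compounds shown here, for (pyridin-2-yl)methoxy there is no measured precedent. A small lowering of the number is therefore expected, a 1.4-fold lower number from compound 2 to compound 4 (0.15 log units; within the scatter), with a result within the scatter of compound 2 quite possible. Compound 4 is estimated at 4500 nM, in a range of 1500 nM to 13000 nM.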

Compound 4, half-maximal effective concentration: > 50000 nM
Compound 4: no number, only a limit; the forecaster's own chance of this, stated with the estimate: 5%; at least 11-fold (1.04 log units) between middle value and limit.
By their numbers in this assay, from the lowest: compounds 2, 3 and 1 (each within the scatter of the next, the first and the last beyond it). At a limit, above all of these: compound 4.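

On the carbonyl carbon, methyl(phenyl)amino cannot be exchanged freely: with the 1-hydroxy-2,2-dimethylpropyl chain kept, (pyridin-2-yl)methoxy gives an at least 7.8-fold higher number from compound 2 to compound 4 (0.89 log units; beyond the scatter) in this assay. Compound 4 has a limit of the assay, not a number: the limit of > 50000 nM in this assay, at which 1 of the 4 values shown sits. The earlier replacement on this carbon, (4-fluorobenzyl)oxy with the (tert-butyl)carbonyl chain kept, gave only a 1.9-fold lower number from compound 1 to compound 3 (0.29 log units; within the scatter), so replacements of this kind do not all behave alike here.

Going by these compounds, those two steps differ in both the entering group and the chain, so it remains open whether the pyridine ring or the hydroxy chain accounts for the contrast. Benzyloxy and (4-fluorobenzyl)oxy on the carbonyl carbon, each paired with the 1-hydroxy-2,2-dimethylpropyl chain, would separate the two.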